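Ring-nitrogen substituent exchange on the shared core

A few compounds are considered here, and "the series" means these few. Any claim that something is new, unique, unknown or untested is made for them only; others in the source may bear on it.

For the measured compounds named here, compound 1 `NC(=O)c1c(NC(=O)c2ccccc2Cl)sc2c1CCN(Cc1ccc([N+](=O)[O-])cc1)C2` is the only member of the series with a numeric result: in a functional assay on MKN-74 cells (Homo sapiens) for antiproliferative activity, with a stated time of 24 h (on this read-out higher numbers stand for weaker inhibition and lower numbers for stronger inhibition), compound 1 gives 31500 nM. Compound 2 `NC(=O)c1c(NC(=O)c2ccc(C(F)(F)F)cc2)sc2c1CCN(Cc1ccc(Cl)cc1)C2` sits at the limit of this assay, where compound 2 gives > 50000 nM; this is a limit, not a number (the limit of > 50000 nM in this assay, at which 1 of the 2 values shown sits). Going by the values given here, since compound 2 differs from compound 1 in more than one place, the two results show only that compound 2 is no stronger than compound 1 in this assay.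

Compound 3 `COc1ccc(NC(=S)N2CCc3c(sc(NC(=O)c4ccccc4Cl)c3C(N)=O)C2)cc1` has not been measured. It differs from compound 1 at the ring nitrogen: a group of 11 heavy atoms (8 carbon, 1 nitrogen, 1 oxygen, 1 sulfur; one six-membered aromatic ring of carbon only) in place of a group of 10 heavy atoms (7 carbon, 1 nitrogen, 2 oxygen; one six-membered aromatic ring of carbon only), on an amine nitrogen in a ring. The group that enters carries one hydrogen-bond donor and a sulfur where the 4-nitrobenzyl had none.

Among the compounds with values here, no step of this kind is measured, so there is nothing to set a direction. The expectation for the step from compound 1 to compound 3 is a change of no more than the usual scatter, estimated as a 1.1-fold lower number from compound 1 to compound 3 (0.05 log units; within the scatter). For compound 3 in this assay the estimate is 28000 nM, within a range of 8000 nM to 90000 nM, with a real chance that only a limit is reported.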

Compound 3, half-maximal inhibitory concentration: 19600 nM
Estimate against measurement, compound 3: 1.4-fold (0.15 log units) above; the measured number falls inside the stated range.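

Working notes on the ring nitrogen: in this assay, the first readable step at this place is a 1.6-fold lower number from compound 1 to compound 3 (0.21 log units; within the scatter). On an amine nitrogen in a ring of the shared core, the 4-nitrobenzyl and the entering group, which carries a sulfur and a hydrogen-bond donor, are therefore not separated by this read-out, although the two groups differ in atoms and in donor count. No measured property in the series bears on this step, so nothing can be said about its origin.

For the compounds shown here, compound 2 gives > 50000 nM, which is a limit and not a number, and it differs from compound 3 in more than one place, so it adds no step and leaves the contribution of each changed place unresolved. Also open, on these data alone, is whether a different group on the same ring nitrogen, such as a small alkyl chain, a benzyl carrying a carboxylic acid or a chain ending in an amine, would move the read-out beyond the usual scatter from compound 1 and compound 3.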